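This account rests on a few compounds, and the source may have more. Where it says the series, first, only, none or still open, it means among the compounds named here.

Compound 1 `CCCOc1ccc2oc(/C=C/[S+](C)[O-])cc(=O)c2c1`: 6200 nM
Compound 2 `C[S+]([O-])/C=C/c1cc(=O)c2cc(OC(=O)C(C)(C)C)ccc2o1`: 8000 nM
Compound 3 `CCCCOc1ccc2oc(/C=C/[S+](C)[O-])cc(=O)c2c1`: 4800 nM

All three share one core and were tested in a functional assay on DLD-1 cells (Homo sapiens) for cytotoxicity, with a stated time of 48 h; on this read-out lower numbers stand for stronger inhibition and higher numbers for weaker inhibition. Among these numbers compound 1 stands second highest; its neighbours differ from it only within the scatter, as the steps of a 1.3-fold higher number from compound 1 to compound 2 (0.11 log units; within the scatter) and a 1.3-fold lower number from compound 1 to compound 3 (0.11 log units; within the scatter) show, and likewise a 1.7-fold lower number from compound 2 to compound 3 (0.22 log units; within the scatter). Compound 4 `C[S+]([O-])/C=C/c1cc(=O)c2cc(Br)ccc2o1` is not yet measured. It differs from compound 1 as follows: bromo in place of propoxy on an aromatic carbon. Among the measured compounds shown here, the measured steps all exchange groups on that oxygen and none moved the number beyond the scatter; no measured step removes the oxygen itself, so the expectation rests on thin ground. The step expected here is a 1.1-fold higher number from compound 1 to compound 4 (0.05 log units; within the scatter), nothing beyond the scatter. Compound 4 is therefore estimated at 7000 nM, with a range from 3000 nM to 16000 nM.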

Compound 4, half-maximal inhibitory concentration: 4500 nM
For compound 4 the middle estimate is 1.6-fold (0.19 log units) above the measured one, within the range that was stated.
By their numbers in this assay, from the lowest: compounds 4, 3, 1 and 2 (each within the scatter of the next).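

Unlike the earlier steps, this change removes the oxygen from the aromatic carbon, and bromo, with one heavy atom, replaces groups of several. Even so, this assay shows no change beyond the scatter, with (a 1.4-fold lower number from compound 1 to compound 4 (0.14 log units; within the scatter)) and (a 1.1-fold lower number from compound 3 to compound 4 (0.03 log units; within the scatter)) and (a 1.8-fold lower number from compound 2 to compound 4 (0.25 log units; within the scatter)). So this position tolerates the loss of that oxygen here, and nothing given explains why.

On these data alone, whether an amine or a carboxylic acid on this carbon would give a number outside the scatter stays open. So does the result with plain hydrogen there.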